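The compounds below may be only part of what the source reports. "The series", "measured", "known", "first", "only" and "open" are said of these compounds alone.

In a functional assay on MDA-MB-435 cells (Homo sapiens) for cytotoxicity, read by MTT assay, with a stated time of 72 h (on this read-out higher numbers stand for weaker inhibition and lower numbers for stronger inhibition), compound 1 `N[C@H]1CC[C@H](Nc2c(C(=O)NCc3ccc(Oc4ccccc4)cc3)nc(Br)c3cccnc23)CC1` gives 4000 nM and compound 2 `N[C@H]1CC[C@H](Nc2c(C(=O)NCc3cccs3)nc(Br)c3cccnc23)CC1` gives 4100 nM so the two stand within the scatter of each other. Compound 3 `N[C@H]1CC[C@H](Nc2c(C(=O)NCc3ccccc3)nc(Br)c3cccnc23)CC1` carries phenyl in place of thiophen-2-yl on a saturated chain carbon bound to an amide-type nitrogen. Going by the values given here, no step between measured compounds covers this change, so the expectation in this assay rests on those two values alone, and no shift in either direction beyond the scatter is expected. The estimated step of a 1.2-fold lower number from compound 2 to compound 3 (0.07 log units; within the scatter) is expected to stay within the scatter. Compound 3 is estimated at 3500 nM with an expected range from 1500 nM to 8000 nM in this read-out.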

Compound 3, half-maximal inhibitory concentration: 7000 nM
Compound 3: the middle estimate sits 2.0-fold (0.30 log units) below what was measured, within the range that was stated.
By their numbers in this assay, from the lowest: compounds 1, 2 and 3 (each within the scatter of the next).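

In this assay, phenyl in place of thiophen-2-yl on a saturated chain carbon bound to an amide-type nitrogen gives a 1.7-fold higher number from compound 2 to compound 3 (0.23 log units; within the scatter), and hydrogen in place of phenoxy on an aromatic carbon gives a 1.8-fold higher number from compound 1 to compound 3 (0.24 log units; within the scatter). Both steps lie within the scatter, so neither change separates these compounds in this read-out. No measured evidence bears on these results. Still open, from the compounds shown here alone, is whether an amine or a carboxylic acid in place of phenyl at this position would give a step beyond the scatter.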